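The source may report more compounds than this note shows. Statements on the series, on what has been measured and on what is new or still open speak of the compounds shown alone.

Of the compounds shown here, three built on one shared core have been tested in a functional assay on ACHN cells (Homo sapiens) for cytotoxicity, read by MTT assay, with a stated time of 48 h; a higher number here means a weaker inhibitor, a lower number a stronger inhibitor. Compound 1 `O=C(Nc1nc2ccc(Cl)cc2s1)c1cc(-c2ccc(F)cc2)n2nc(-c3ccccc3)cc2n1` gives 13800 nM. Compound 2 `O=C(Nc1nc2ccc(F)cc2s1)c1cc(-c2ccc(F)cc2)n2nc(-c3ccccc3)cc2n1` gives 35500 nM, and compound 3 `COc1cc(-c2cc(C(=O)Nc3nc4ccc(F)cc4s3)nc3cc(-c4ccccc4)nn23)cc(OC)c1OC` gives 32400 nM. Among these three numbers compound 2 stands highest, meaning it is the weakest inhibitor of the set as far as the scatter allows such a call: the step of a 2.6-fold higher number from compound 1 to compound 2 (0.41 log units; beyond the scatter) lies beyond the scatter, whereas the step of a 1.1-fold lower number from compound 2 to compound 3 (0.04 log units; within the scatter) does not, so compound 2 and compound 3 cannot be told apart.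

Compound 4 `COc1ccc2nc(NC(=O)c3cc(-c4ccc(F)cc4)n4nc(-c5ccccc5)cc4n3)sc2c1` differs from compound 2 at a single place: methoxy in place of fluoro on an aromatic carbon. Among the compounds with values here, only one measured step touches the same position, the exchange a 2.6-fold higher number from compound 1 to compound 2 (0.41 log units; beyond the scatter), which shows that swapping one small group for another at this spot can move the number by a modest but real amount. Within the data shown here, no measured compound carries a methoxy there, so the direction of the new change cannot be read from the data; the one exchange known at this position happens to have moved the number downward when a larger group was present. A modest step is therefore expected for compound 4, a 1.4-fold lower number from compound 2 to compound 4 (0.15 log units; within the scatter), most likely downward. Compound 4 is estimated at 25000 nM, within a range from 9000 nM to 60000 nM.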

Compound 4, half-maximal inhibitory concentration: 26300 nM
Estimate against measurement, compound 4: 1.1-fold (0.02 log units) below, and the stated range covers the measured number.
By their numbers in this assay, from the lowest: compounds 1, 4, 3 and 2 (each within the scatter of the next, the first and the last beyond it).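

Replacing the fluoro of the 6-fluoro-1,3-benzothiazol-2-yl group with methoxy brings in one more heavy atom and a hydrogen-bond acceptor, yet it gives a 1.3-fold lower number from compound 2 to compound 4 (0.13 log units; within the scatter), a change too small to tell from no change at all. Set against chloro, the result is equally unresolved, with a 1.9-fold higher number from compound 1 to compound 4 (0.28 log units; within the scatter), so compound 4 cannot be separated from either compound 1 or compound 2, even though those two differ from each other by more than the scatter. This position therefore accepts a group joined through oxygen with no clear shift from either halogen, although the data offer no explanation for this pattern.

Going by these compounds, whether the number can move further at this position remains open, as an amine, a carboxylic acid or a longer chain such as butoxy would test a quite different kind of group there. On these data alone, it is also open whether methoxy in place of fluoro would behave the same way alongside the 3,4,5-trimethoxyphenyl group of compound 3 rather than the 4-fluorophenyl group of compound 2.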